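The source may report more compounds than this note shows. Statements on the series, on what has been measured and on what is new or still open speak of the compounds shown alone.

Measured compounds:

Compound 1 `Cn1cc(C(=O)N2CCC(C(N)=O)CC2)c2ccccc21`: in an ADME assay for permeability, using PAMPA, at pH 7.4 (a higher number here means that the compound crosses the layer faster, a lower number that the compound crosses the layer more slowly), compound 1 gives 0.2 10^-6 cm/s.
Compound 2 `O=C(Cn1ccccc1=O)Nc1cc2ccccc2[nH]1`: in this assay compound 2 gives 0.1 10^-6 cm/s.
Compound 3 `NC(=O)C1CCN(C(=O)c2c[nH]c3ccccc23)CC1`: in this assay compound 3 gives < 0.01 10^-6 cm/s, which is a limit of the assay and not a number.

Compound 1 and compound 3 share a core and differ in one place only, described as methyl in place of hydrogen on an aromatic nitrogen. This change gave an at least 20-fold higher number from compound 3 to compound 1 (1.30 log units; beyond the scatter). The size of that step is only a floor because compound 3 sits at the limit of < 0.01 10^-6 cm/s in this assay, at which 1 of the 3 values shown sits. Compound 2 rests on a different core; how its core differs from that of compound 3 is not broken down here. Within the two numbers that are plain numbers, compound 2 and compound 1 lie within the scatter of each other, so no order between them can be read.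

Compound 4 `Cn1c(NC(=O)Cn2ccccc2=O)cc2ccccc21` has not yet been measured in this assay. It differs from compound 2 by methyl in place of hydrogen on an aromatic nitrogen. Within the data shown here, this is the same kind of change as the one from compound 3 to compound 1, but not the same: in compound 4 the methyl enters next to the ring atom that bears a large group, whereas in compound 1 it enters two ring bonds from the ring atom that bears a large group. Resting on the step of an at least 20-fold higher number from compound 3 to compound 1 (1.30 log units; beyond the scatter), the change from compound 2 to compound 4 is expected to raise the number, with an estimated 10-fold higher number from compound 2 to compound 4 (1.00 log units; beyond the scatter). For compound 4 the estimated value in this assay is 1 10^-6 cm/s, expected to fall between 0.3 10^-6 cm/s and 4 10^-6 cm/s.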

Compound 4, apparent permeability in the ADME assay: 3.3 10^-6 cm/s
Estimate against measurement, compound 4: 3.3-fold (0.52 log units) below, within the range that was stated.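

In the ADME assay, methyl in place of hydrogen on an aromatic nitrogen gave a 33-fold higher number from compound 2 to compound 4 (1.52 log units; beyond the scatter), so the change raised the number on the core of compound 2 as well as on the core of compound 1, and whether the two steps differ in size cannot be said: the same change on two cores in the ADME assay, an at least 20-fold higher number (1.30 log units; beyond the scatter) from compound 3 to compound 1 and a 33-fold higher number (1.52 log units; beyond the scatter) from compound 2 to compound 4; the limit leaves it open whether they differ. The value of compound 3 is a limit of the assay and not a number: the limit of < 0.01 10^-6 cm/s in the ADME assay, at which 1 of the 4 values shown sits. In a physicochemical assay for lipophilicity, read by HPLC, measured as octanol-water partition, at pH 11 (a lower number here means a more polar compound, a higher number a more lipophilic compound), compound 2 gives 1 and compound 4 gives 1.5. The same change also gave a more lipophilic compound, but a single pair cannot tell how much of the rise in the ADME assay goes with that shift, and two cores are too few to make a rule for any further core: the measured distribution coefficient of compound 2, 1, and of compound 4, 1.5, a number 0.50 log units higher (beyond the scatter).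

The compounds shown carry only hydrogen or methyl on this nitrogen, so they leave open whether a longer chain there, such as ethyl or propyl, would raise the number further or lose the gain. They also leave open what a chain ending in an amine or a carboxylic acid on the same nitrogen would do to the number in the ADME assay.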